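A few compounds are considered here, and "the series" means these few. Any claim that something is new, unique, unknown or untested is made for them only; others in the source may bear on it.

Compound 1, `CCC(C)N(C(=O)[C@H](CC(=O)OC)NC(=O)OC(C)(C)C)C1(C(=O)NCc2ccccc2)CCN(Cc2ccccc2)CC1`, and compound 2, `COC(=O)C[C@H](NC(=O)OC(C)(C)C)C(=O)N(C1CC1)C1(C(=O)NCc2ccccc2)CCN(Cc2ccccc2)CC1`, share a core and differ in one place: cyclopropyl in place of sec-butyl on an amide-type nitrogen. In a functional assay on L1210 cells (Mus musculus) for inhibition, with a stated time of 48 h (a higher number here means a weaker inhibitor, a lower number a stronger inhibitor), compound 1 gives 20000 nM, and in this assay compound 2 gives 14000 nM. The step between them, a 1.4-fold lower number from compound 1 to compound 2 (0.15 log units; within the scatter), is small enough that the two compounds cannot be ranked against each other on this measurement alone.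

Compound 3, `CCC(C)N(C(=O)[C@@H](NC(=O)OCc1ccccc1)[C@@H](C)CC)C1(C(=O)NCc2ccccc2)CCN(Cc2ccccc2)CC1`, carries a different set of groups on the same kind of scaffold; the difference between the core of compound 3 and the core of compound 1 is not broken down here. In this assay compound 3 gives 83000 nM, the highest number of the three measured compounds, and its distance to compound 1 and to compound 2 lies beyond the usual scatter in both cases.

Compound 4, `CC[C@H](C)[C@H](NC(=O)OCc1ccccc1)C(=O)N(C1CC1)C1(C(=O)NCc2ccccc2)CCN(Cc2ccccc2)CC1`, is related to compound 3 by the same change that links compound 1 to compound 2: cyclopropyl in place of sec-butyl on an amide-type nitrogen. The place of the change reads the same in both pairs. Among the measured compounds shown here, the only evidence for what this change does comes from the single step of a 1.4-fold lower number from compound 1 to compound 2 (0.15 log units; within the scatter), which stayed within the scatter, so compound 4 is expected to sit close to compound 3, with the step from compound 3 to compound 4 estimated as a 1.3-fold lower number from compound 3 to compound 4 (0.11 log units; within the scatter) because the earlier step of a 1.4-fold lower number from compound 1 to compound 2 (0.15 log units; within the scatter) was of that size. On that basis compound 4 is expected to give about 65000 nM in this assay, most likely between 25000 nM and 160000 nM.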

Compound 4, half-maximal inhibitory concentration: 11000 nM
Beside the measured number, compound 4's estimate is 5.9-fold (0.77 log units) above it, outside the stated range (below it).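

In this assay, cyclopropyl in place of sec-butyl on an amide-type nitrogen gives a 7.5-fold lower number from compound 3 to compound 4 (0.88 log units; beyond the scatter), a step that on the core of compound 3 stands clear of the usual scatter. Set beside the same change on the core of compound 1, the size of the step does not carry over from one core to the other: the same change on two cores in this assay, a 1.4-fold lower number (0.15 log units; within the scatter) from compound 1 to compound 2 and a 7.5-fold lower number (0.88 log units; beyond the scatter) from compound 3 to compound 4, 5.3-fold (0.72 log units) apart, beyond the scatter of two such steps. This shows that in these two pairs the outcome of the change differs with the core that carries it, but two pairs do not show which of the differences between the cores goes with the larger step, and they give no rule for predicting the step on a further core.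

The compounds shown carry only sec-butyl or cyclopropyl on that nitrogen, so it remains open how a smaller or larger group there, such as an ethyl or a cyclohexyl group, would behave on either core. On these data alone, it also remains open whether the step would hold if the carbamate gave way to a free amine, or if the methyl ester of compound 1 and compound 2 gave way to a carboxylic acid.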